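Notes on compound 3: exchange of the hydroxyphenyl group

The source may hold more compounds than are shown below. What is called first, only, known or untested is meant among the compounds shown, and "the series" means these compounds.

In a functional assay on Hs-578T cells (Homo sapiens) for inhibition (on this read-out higher numbers stand for weaker inhibition of growth and lower numbers for stronger inhibition of growth), compound 1 (`O=C(/C=C/c1cccc(O)c1)c1cccc(-n2cc(-c3ccccc3)[nH]c2=O)c1`) gives 6140 nM. In the same read-out, compound 2 (`O=C(/C=C/c1cccc(O)c1)c1cccc(-n2cc(-c3ccc(Cl)cc3)[nH]c2=O)c1`) gives 4000 nM. Among the compounds with values here, the only measured step is a 1.5-fold lower number from compound 1 to compound 2 (0.19 log units; within the scatter), with chloro in place of hydrogen on an aromatic carbon, so compound 2 stands level with compound 1 on the numbers so far.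

Compound 3 (`COc1cc(/C=C/C(=O)c2cccc(-n3cc(-c4ccc(Cl)cc4)[nH]c3=O)c2)ccc1O`) differs from compound 2 as follows: 4-hydroxy-3-methoxyphenyl in place of 3-hydroxyphenyl on a double-bonded chain carbon bound to a double-bonded chain carbon. In words, 4-hydroxy-3-methoxyphenyl stands in place of 3-hydroxyphenyl on a double-bonded chain carbon bound to a double-bonded chain carbon. Within the data shown here, the measured step is a different change and offers only a weak guide, and no measured pair exchanges this group. No shift beyond the scatter is therefore expected in this assay, and no direction can be argued. The expected step is a 1.1-fold lower number from compound 2 to compound 3 (0.06 log units; within the scatter). For compound 3 the estimated value is 3500 nM, with an expected range of 1200 nM to 10000 nM.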

Compound 3, concentration for 50% growth inhibition: 4670 nM
Beside the measured number, compound 3's estimate is 1.3-fold (0.13 log units) below it; the range from low to high includes it.
By their numbers in this assay, from the lowest: compounds 2, 3 and 1 (each within the scatter of the next).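

In this assay, within the data shown here, the exchange of 3-hydroxyphenyl for 4-hydroxy-3-methoxyphenyl gives a 1.2-fold higher number from compound 2 to compound 3 (0.07 log units; within the scatter), the first measured step at this position, since the earlier compounds both carry 3-hydroxyphenyl. On this one step, the position on a double-bonded chain carbon bound to a double-bonded chain carbon accepts the larger group, with 9 heavy atoms in place of 7, without a shift beyond the scatter. No measurement is available that could explain this result.

No step shown so far lies beyond the scatter, so it remains unknown what, if anything, moves this read-out at this position. From the compounds shown here alone, it also remains open whether an unsubstituted phenyl, a pyridyl or a benzoic acid group in place of the hydroxyphenyl group would shift the number beyond the scatter.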